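The source may hold more compounds than are shown below. What is called first, only, known or untested is meant among the compounds shown, and "the series" means these compounds.

In a functional assay on MCF-10A cells (Homo sapiens) for antiproliferative activity, with a stated time of 48 h (on this read-out higher numbers stand for an effect only at larger amounts of compound and lower numbers for an effect already at smaller amounts), compound 1 (`COc1ccc2nc(C)cc(NCc3ccc(C(F)(F)F)cc3)c2c1`) gives 7600 nM and compound 2 (`COc1ccc(CNc2cc(C)nc3ccc(OC)cc23)cc1`) gives 9700 nM on the same read-out, so the two values of the series lie within the scatter of each other. Compound 3 (`COc1ccc2nc(C)cc(NCc3ccc(OC(F)F)cc3)c2c1`) departs from compound 2 at one place: difluoromethyl in place of methyl on an oxygen on an aromatic ring (methoxy to difluoromethoxy). For the measured compounds named here, the only measured step bearing on this is a 1.3-fold higher number from compound 1 to compound 2 (0.11 log units; within the scatter) for methoxy in place of trifluoromethyl on an aromatic carbon. No shift beyond the scatter is therefore expected in this assay here. The step expected is a 1.2-fold lower number from compound 2 to compound 3 (0.08 log units; within the scatter) by estimate. Compound 3 is estimated at 8000 nM within an expected range of 3500 nM to 18000 nM for now.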

Compound 3, half-maximal effective concentration: 14700 nM
For compound 3 the middle estimate is 1.8-fold (0.26 log units) below the measured one, within the range that was stated.
By their numbers in this assay, from the lowest: compounds 1, 2 and 3 (each within the scatter of the next).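

In this assay, replacing methyl with difluoromethyl on the oxygen gives a 1.5-fold higher number from compound 2 to compound 3 (0.18 log units; within the scatter) and stays within the scatter, as does the comparison with trifluoromethyl, which gives a 1.9-fold higher number from compound 1 to compound 3 (0.29 log units; within the scatter) and also stays within it. Trifluoromethyl, methoxy and difluoromethoxy at this place thus give numbers that the scatter does not separate across compounds 1, 2 and 3, a picture one earlier step could not show. No measurement available here accounts for these numbers.

Going by these compounds, whether an amine or a carboxylic acid at this place would move the number beyond the scatter remains open. Also open, on these data alone, is whether changes to the shared core would do so.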